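Hydroxy added to the methyl-substituted ring of a chalcone catechol

The source may report more compounds than this note shows. Statements on the series, on what has been measured and on what is new or still open speak of the compounds shown alone.

Within the data shown here, compound 1 `Cc1cccc(C(=O)/C=C/c2ccc(O)c(O)c2)c1` gives 27 nM in an assay on RBL-1 cells for inhibition of Polyunsaturated fatty acid 5-lipoxygenase (Rattus norvegicus) (a lower number here means a stronger inhibitor, a higher number a weaker inhibitor), the highest of the two numbers so far. Among the measured compounds shown here, compound 2 `CN(C)c1cccc(C(=O)/C=C/c2ccc(O)c(O)c2)c1` gives 9.8 nM, and the change a 2.8-fold lower number from compound 1 to compound 2 (0.44 log units; beyond the scatter) is the only step measured. For the measured compounds named here, compound 3 `Cc1ccc(O)c(C(=O)/C=C/c2ccc(O)c(O)c2)c1` carries a (hydroxy in place of hydrogen on an aromatic carbon); no measured step concerns a hydroxy entering at this place, and the step from compound 1 to compound 2 alters a different group, so it bears only loosely. For compound 3 no step beyond the scatter is therefore expected, a 1.2-fold lower number from compound 1 to compound 3 (0.09 log units; within the scatter). Compound 3 is estimated at 22 nM with a range of 7 nM to 70 nM.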

Compound 3, half-maximal inhibitory concentration: 39 nM
For compound 3 the middle estimate is 1.8-fold (0.25 log units) below the measured one; low and high end bracket the measured number.
By their numbers in this assay, from the lowest: compound 2; then compounds 1 and 3 (each within the scatter of the next).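

Hydroxy in place of hydrogen on an aromatic carbon, ortho to a large group and para to a methyl group, gives a 1.4-fold higher number from compound 1 to compound 3 (0.16 log units; within the scatter) in this assay and so shows that this position accepts a hydroxy without a step beyond the scatter. Among these compounds, this is the first reading at this place on the ring of compound 1. No available data account for this result. From the compounds shown here alone, whether a methoxy group or an amine at the same position would also stay within the scatter remains open. Also open, going by these compounds, is whether the hydroxy would behave alike with dimethylamino in place of the methyl group, as in compound 2.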